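Adding an Ethyl Group to the Tightest Binder

The source may hold more compounds than are shown below. What is called first, only, known or untested is meant among the compounds shown, and "the series" means these compounds.

Of the compounds shown here, three have so far been tested in an assay on CHO cells for displacement of a labelled ligand from prostaglandin E2 receptor EP4 subtype (Mus musculus), read by scintillation counting, with a stated time of 60 min; on this read-out lower numbers stand for stronger inhibition and higher numbers for weaker inhibition. Compound 1 `O=C(O)CCCSCCN1C(=O)OC[C@@H]1/C=C/[C@@H](O)Cc1ccccc1` gives 4.2 nM, compound 2 `O=C(O)CCCSCCN1C(=O)OC[C@@H]1/C=C/[C@@H](O)Cc1cccc(C(F)(F)F)c1` gives 2 nM, and compound 3 `O=C(O)CCCSCCN1C(=O)SC[C@@H]1/C=C/[C@@H](O)Cc1ccccc1` gives 0.65 nM, the lowest number of the three and beyond the scatter from both others. Compound 4 `CCc1cccc(C[C@H](O)/C=C/[C@H]2CSC(=O)N2CCSCCCC(=O)O)c1` differs from compound 3 by ethyl in place of hydrogen on an aromatic carbon. For the measured compounds named here, the one measured step of a comparable kind, a group added on an aromatic carbon of that ring, is a 2.1-fold lower number from compound 1 to compound 2 (0.32 log units; beyond the scatter). On that basis, for compound 4 a similarly modest lowering is expected, namely a 1.4-fold lower number from compound 3 to compound 4 (0.16 log units; within the scatter). In this assay compound 4 is therefore estimated at 0.45 nM, with a likely range from 0.15 nM to 1.3 nM.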

Compound 4, inhibition constant: 0.88 nM
For compound 4 the middle estimate is 2.0-fold (0.29 log units) below the measured one, and the stated range covers the measured number.
By their numbers in this assay, from the lowest: compounds 3 and 4 (each within the scatter of the next); then compound 2; then compound 1.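

Ethyl in place of hydrogen on an aromatic carbon, meta to a large group, gives a 1.4-fold higher number from compound 3 to compound 4 (0.13 log units; within the scatter) in this assay. For the compounds shown here, this shows that, on the core of compound 3, a group of two carbons can stand at this place on the ring with the number staying within the usual scatter, whereas the earlier added group, trifluoromethyl, was seen only on the core of compound 1. No measurement shown here explains this result. The compounds shown leave open how an amine, a methoxy group or a longer chain would read at this place. They also leave open how trifluoromethyl would read on the core of compound 3.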